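Carboxymethylamino for carboxymethoxy: an expected outcome

This account rests on a few compounds, and the source may have more. Where it says the series, first, only, none or still open, it means among the compounds named here.

Compound 1, `C/C(=N\OCC(=O)O)c1cccc(Cl)c1`: in a functional assay on the whole organism for inhibition, with Rattus norvegicus as the target, read by paw edema, with stated times of 1 h and 3 h, at a dose of 50 mg/kg by the oral route (on this read-out higher numbers stand for more inhibition at the one dose given (going by the name of the read-out) and lower numbers for less inhibition), compound 1 gives 20%.
Compound 2, `C/C(=N\OCC(=O)O)c1ccc(S(C)(=O)=O)cc1`: in this assay compound 2 gives 20%.
Compound 3, `C/C(=N\OCC(=O)O)c1ccc(C2CCCCC2)c(Cl)c1`: in this assay compound 3 gives < 20%, which is a limit of the assay and not a number.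

Compound 3 therefore stands at the low end of the three readings shown, with only a limit to its name. Compounds 1 and 2 give the same number as each other. Among the measured compounds shown here, the one measured step, a number no higher from compound 1 to compound 3 (the limit leaves the size open), puts cyclohexyl in place of hydrogen on an aromatic carbon, and its size cannot be read because the limit of < 20% in this assay, at which 1 of the 3 values shown sits, cuts the reading off.

Compound 4, `C/C(=N\NCC(=O)O)c1ccc(C2CCCCC2)c(Cl)c1`, differs from compound 3 in one place: (carboxymethyl)amino in place of carboxymethoxy on a double-bonded nitrogen. For the measured compounds named here, no measured step touches a (carboxymethyl)amino or a carboxymethoxy group, so none of the steps bears on this change, and the expected step that the limit leaves unreadable from compound 3 to compound 4 is estimated as nothing beyond the usual scatter. In this assay compound 4 is therefore expected to give about 15%, estimated to fall between 5% and 30%.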

Compound 4, a percentage reported as inhibition, in the whole organism at one dose (the size of the read-out at that dose, not a potency): < 20%
Compound 4 was reported as a limit (the forecaster's own chance of this, stated with the estimate: 55%); the middle value does not contradict the limit.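

In this assay compound 3 and compound 4 are both reported only as limits, so no step can be read from one to the other: the limit of < 20% in this assay, at which 2 of the 4 values shown sit.

The compounds shown leave open whether (carboxymethyl)amino in place of carboxymethoxy on a double-bonded nitrogen changes the inhibition at all.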